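Phenoxy in Place of Trifluoromethoxy: Solubility Outlook

The source may hold more compounds than are shown below. What is called first, only, known or untested is meant among the compounds shown, and "the series" means these compounds.

Compound 2 `CNC(=O)c1cc(Oc2ccc3nc(Nc4ccc(OC(F)(F)F)cc4)ncc3c2)ccn1` is the starting point. In a physicochemical assay for solubility, at pH 7 (on this read-out higher numbers stand for higher solubility and lower numbers for lower solubility), compound 2 gives < 1000 nM, which is a limit of the assay and not a number. Compound 1 `CNC(=O)c1cc(Oc2ccc3nc(Nc4ccc(C(F)(F)F)cc4)ncc3c2)ccn1` in this assay gives < 1000 nM, also a limit. The step that the two limits leave unreadable from compound 1 to compound 2 therefore has no readable size, since both values sit at the limit of < 1000 nM in this assay, at which 2 of the 2 values shown sit. Compound 3 `CNC(=O)c1cc(Oc2ccc3nc(Nc4ccc(Oc5ccccc5)cc4)ncc3c2)ccn1` carries phenyl in place of trifluoromethyl on an oxygen on an aromatic ring. Among the measured compounds shown here, no measured step reads on this change, so no direction beyond the scatter can be drawn. Compound 3 is estimated at 400 nM, between 80 nM and 1500 nM. The expected step is a step that the limit leaves unreadable from compound 2 to compound 3, most likely leaving the value at the limit.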

Compound 3, solubility: < 1000 nM
Compound 3: a limit, no number; the forecaster's own chance of this, stated with the estimate: 80%; the middle value is on the limit's open side.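

No new step can be read from compound 3 to compound 1 or compound 2, because all three values are limits and not numbers: the limit of < 1000 nM in this assay, at which 3 of the 3 values shown sit.

Going by these compounds, how compound 1, compound 2 and compound 3 truly compare in this assay stays open.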